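A few compounds are considered here, and "the series" means these few. Any claim that something is new, unique, unknown or untested is made for them only; others in the source may bear on it.

Measured compounds:
- compound 1 `COc1nc(CC(O)(CO)CO)c(C)c(OC)n1`; in a functional assay on MIA PaCa-2 cells (Homo sapiens) for antiproliferative activity, read by MTT assay, with a stated time of 72 h (on this read-out lower numbers stand for stronger inhibition and higher numbers for weaker inhibition), compound 1 gives > 100000 nM, which is a limit of the assay and not a number.
- compound 2 `COc1nc(CC(O)(COC(C)=O)COC(C)=O)c(C)c(OC)n1`; in this assay compound 2 gives > 100000 nM, again a limit and not a number.

Among the compounds with values here, compound 2 thus stands at the limit rather than at a measured value, and the only other value shown sits at the same limit (the limit of > 100000 nM in this assay, at which 2 of the 2 values shown sit). Within the data shown here, no step between measured compounds is available from these two.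

Compound 3 `COc1nc(CC(F)(COC(C)=O)COC(C)=O)c(C)c(OC)n1` differs from compound 2 by a single change: fluoro in place of hydroxy on a saturated chain carbon bound to three saturated chain carbons. Nothing measured here speaks to what this exchange does in this assay. Among the measured compounds shown here, with compound 2 at the limit and no step to draw on, compound 3 is expected to stay near the limit as well, so the step that the limit leaves unreadable from compound 2 to compound 3 is estimated as none beyond the scatter. For compound 3 the estimated value in this assay is 150000 nM, with a range from 50000 nM to 500000 nM, and most likely only a limit will be reported.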

Compound 3, half-maximal inhibitory concentration: > 100000 nM
Compound 3 ended at the assay's limit; the forecaster's own chance of this, stated with the estimate: 85%; the middle value is on the limit's open side.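

No step can be read from compound 2 to compound 3, as both stand at a limit and not at a number: the limit of > 100000 nM in this assay, at which 3 of the 3 values shown sit. The compounds shown leave open what fluoro in place of hydroxy does in this assay, and whether any close analogue gives a measurable value there.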